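This account rests on a few compounds, and the source may have more. Where it says the series, first, only, none or still open, it means among the compounds named here.

Measured so far:
compound 1 `O=S(=O)(NCC1COC1)c1cccc(-c2ccc3nccc(-c4ccncc4)c3n2)c1`: 20000 nM
compound 2 `c1cc(-c2ccnc3ccc(NC4CC4)nc23)ccn1`: 90000 nM
compound 3 `CN1CCN(c2ccnc3ccc(-c4cccc(S(N)(=O)=O)c4)nc23)CC1`: 200000 nM

All three values come from a physicochemical assay for solubility, read by HPLC, using the shake flask method, measured as kinetic solubility, with a stated time of 20 h, at pH 6.5, tested at 200 uM; on this read-out lower numbers stand for lower solubility and higher numbers for higher solubility. Compound 1 stands lowest of the three. Compound 2 and compound 3 both read higher, and each gap to compound 1 lies beyond the usual scatter of the measurement.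

Compound 4 `O=S(=O)(c1cccc(-c2ccc3nccc(-c4ccncc4)c3n2)c1)N1CC[C@H](O)C1` has not yet been measured. It differs from compound 1 on a sulfonyl sulfur, where 3-hydroxypyrrolidin-1-yl stands in place of ((oxetan-3-yl)methyl)amino: 3-hydroxypyrrolidin-1-yl in place of ((oxetan-3-yl)methyl)amino on a sulfonyl sulfur. The two compounds have the same atoms, joined differently, and the entering group carries a defined stereocentre.

For the measured compounds named here, no measured pair gives a direct read on this kind of change, so the expectation rests on compound 1 as the anchor. With compound 1 at 20000 nM, the low end of the measured values, a small upward step in this assay is expected, and it may well stay within the scatter. The expected change is a 1.5-fold higher number from compound 1 to compound 4 (0.18 log units; within the scatter). For compound 4 the estimated value is 30000 nM, with an expected range from 9000 nM to 100000 nM.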

Compound 4, solubility: 20000 nM
For compound 4 the middle estimate is 1.5-fold (0.18 log units) above the measured one; measured number inside the range.
By their numbers in this assay, from the lowest: compounds 1 and 4 (each within the scatter of the next); then compound 2; then compound 3.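

In this assay, 3-hydroxypyrrolidin-1-yl in place of ((oxetan-3-yl)methyl)amino on a sulfonyl sulfur gives no change at the digits printed from compound 1 to compound 4 (within the scatter), the only single-place step among the compounds shown. Both groups count 6 heavy atoms, 1 hydrogen-bond donor and 1 hydrogen-bond acceptor, so this step reads a rearrangement of the same atoms at this position: a four-membered non-aromatic ring leaves, while a five-membered non-aromatic ring and a defined stereocentre enter, and the read-out stays within the scatter. No measurement at hand accounts for this result.

Open, as far as these compounds go, is how the read-out responds at this sulfonyl sulfur to groups with different atoms, such as a carboxylic acid-bearing chain or a primary amine on a longer chain, and to the opposite stereocentre of 3-hydroxypyrrolidin-1-yl. Compound 2 and compound 3 differ from compound 1 in more than one place, so nothing shown ties their higher numbers to any single group.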